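A few compounds are considered here, and "the series" means these few. Any claim that something is new, unique, unknown or untested is made for them only; others in the source may bear on it.

Compound 1 (`CC1=CC[C@H]2[C@H](CC[C@]2(C)O)C(C)(C)[C@@H]1CC[C@H]1[C@]2(C)CC[C@H](OC(=O)c3ccncc3)C(C)(C)O[C@H]2CC[C@@]1(C)O`) carries a pyridin-4-yl group on a carbonyl carbon. In a functional assay on MCF7 cells (Homo sapiens) for antiproliferative activity, read by MTT assay, with a stated time of 72 h (a lower number here means a stronger inhibitor, a higher number a weaker inhibitor), compound 1 gives 25300 nM as its half-maximal inhibitory concentration. Compound 2 (`CC(=O)O[C@H]1CC[C@]2(C)[C@H](CC[C@@](C)(O)[C@H]2CC[C@@H]2C(C)=CC[C@@H]3C(C)=CC[C@@H]3C2(C)C)OC1(C)C`), which has an acetyl group and a core that is not identical, gives 43500 nM in this assay, and these two values lie within the scatter of each other. Compound 1 therefore stands level with compound 2. Compound 3 (`CC1=CC[C@H]2[C@@H]1CC=C(C)[C@@H](CC[C@H]1[C@]3(C)CC[C@H](OCc4ccccc4)C(C)(C)O[C@H]3CC[C@@]1(C)O)C2(C)C`) is reported as > 50000 nM here, which is a limit of the assay and not a number.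

Compound 4 (`CC1=CC[C@H]2[C@H](CC[C@]2(C)O)C(C)(C)[C@@H]1CC[C@H]1[C@]2(C)CC[C@H](OC(=O)NCc3ccccc3)C(C)(C)O[C@H]2CC[C@@]1(C)O`) has benzylamino in place of pyridin-4-yl on a carbonyl carbon. Among the compounds with values here, no measured pair makes this exact change. From the compounds shown here alone, the nearest evidence is benzyl in place of acetyl on an oxygen, which gave an at least 1.1-fold higher number from compound 2 to compound 3 (0.06 log units; that floor lies within the scatter) in this assay, and that step ends on a limit, so its true size stays open. The values also sit close to the limit of > 50000 nM in this assay, at which 1 of the 3 values shown sits, and compound 4 may likewise be reported only as a limit. No step beyond the scatter is expected, and the estimated change, a small rise in the number, is a 1.3-fold higher number from compound 1 to compound 4 (0.10 log units; within the scatter) in this assay as a working figure. For compound 4 the expected value is 32000 nM with an estimated range from 15000 nM to 50000 nM.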

Compound 4, half-maximal inhibitory concentration: 24500 nM
For compound 4 the middle estimate is 1.3-fold (0.12 log units) above the measured one; low and high end bracket the measured number.
By their numbers in this assay, from the lowest: compounds 4, 1 and 2 (each within the scatter of the next). At a limit, above all of these: compound 3.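

In this assay, within the data shown here, the swap at this position gives a 1.0-fold lower number from compound 1 to compound 4 (0.01 log units; within the scatter), and this is the first step here with a measured number at both ends, since the earlier step between compound 2 and compound 3 ended on a limit. The carbonyl carbon thus carries either pyridin-4-yl or benzylamino with no change beyond the scatter, although the entering group has more heavy atoms, an aromatic ring of carbon only and a hydrogen-bond donor. These differences arrive together in one swap, so the result shows only that their combined effect stays within the scatter, and it cannot separate them.

From the compounds shown here alone, whether an amine or a carboxylic acid in place of the aromatic ring, or a longer chain carrying that ring, would move the number beyond the scatter remains open. How far the number could rise also remains open, as compound 3 is reported only as a limit, which is not a number: the limit of > 50000 nM in this assay, at which 1 of the 4 values shown sits.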